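Removing the Chloro Group from the Hydroxyphenyl-Bearing Core

A few compounds are considered here, and "the series" means these few. Any claim that something is new, unique, unknown or untested is made for them only; others in the source may bear on it.

Compound 3 `N#Cc1c(-c2ccc(Cl)cc2)nc2c(c(-c3ccccc3)nn2-c2ccccc2)c1-c1ccc(O)cc1` carries a 4-chlorophenyl on the shared core; in a functional assay on MV4-11 cells (Homo sapiens) for antiproliferative activity, read by resazurin assay, with a stated time of 72 h (a higher number here means a weaker inhibitor, a lower number a stronger inhibitor), compound 3 gives 25100 nM, the higher of the two numbers obtained, the nearer being compound 1 `N#Cc1c(-c2ccc(F)cc2)nc2c(c(-c3ccccc3)nn2-c2ccccc2)c1-c1ccc(O)cc1`, which gives 11600 nM in this assay. Compound 2 `COc1ccc(-c2c(C#N)c(-c3ccccc3)nc3c2c(-c2ccccc2)nn3-c2ccccc2)cc1OC` reaches only the limit > 25000 nM in this assay. One of the three values thus sits at a limit (the limit of > 25000 nM in this assay, at which 1 of the 3 values shown sits). Going by the values given here, the single measured step, a 2.2-fold higher number from compound 1 to compound 3 (0.34 log units; beyond the scatter), concerns this same ring. Compound 4 `N#Cc1c(-c2ccccc2)nc2c(c(-c3ccccc3)nn2-c2ccccc2)c1-c1ccc(O)cc1` differs from compound 3 by hydrogen in place of chloro on an aromatic carbon. Because compound 1 gives 11600 nM with the smaller halogen, a modest fall in number is expected, within the size of that step. Compound 4 is estimated at 13000 nM (5000 nM to 30000 nM) in this assay. This amounts to an expected 1.9-fold lower number from compound 3 to compound 4 (0.29 log units; within the scatter).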

Compound 4, half-maximal inhibitory concentration: 26100 nM
The estimate for compound 4 lay 2.0-fold (0.30 log units) below the measured number; measured number inside the range.
By their numbers in this assay, from the lowest: compound 1; then compounds 3 and 4 (each within the scatter of the next).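

In this assay, hydrogen in place of chloro gives a 1.0-fold higher number from compound 3 to compound 4 (0.02 log units; within the scatter), so these two groups cannot be told apart at this position on the ring. Fluoro alone stands apart among the three groups compared here, with a 2.3-fold higher number from compound 1 to compound 4 (0.35 log units; beyond the scatter), a modest step that shows the halogen itself is not what lowers the number, since chloro does not. Compound 2 stands at a limit, so its step to compound 4 cannot be read: the limit of > 25000 nM in this assay, at which 1 of the 4 values shown sits.

Going by these compounds, whether an amine, a methoxy group or a carboxylic acid at this position would lower the number remains open. So does whether any group here could take the number far below that of compound 1, 11600 nM.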